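A single trifluoromethyl stripped from the weakest ring

The compounds below may be only part of what the source reports. "The series", "measured", "known", "first", "only" and "open" are said of these compounds alone.

Of the compounds shown here, three sharing one core have been measured in a functional assay on HeLa cells (Homo sapiens) for inhibition; a lower number here means a stronger inhibitor, a higher number a weaker inhibitor. Compound 1 `O=C1C=CC(OCC(F)(F)F)N1c1cc(Cl)cc(Cl)c1` gives 5920 nM, compound 3 `O=C1C=CC(OCC(F)(F)F)N1c1cc(F)cc(F)c1` gives 8460 nM, and compound 2 `O=C1C=CC(OCC(F)(F)F)N1c1ccc(C(F)(F)F)cc1` gives 36200 nM. Compound 2 stands with the highest number of the three: its number is beyond the scatter from both compound 3, the nearest, and compound 1, the furthest, so compound 2 is the weakest inhibitor in this set.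

The next compound, compound 4 `O=C1C=CC(OCC(F)(F)F)N1c1ccccc1`, differs from compound 2 in one place: hydrogen in place of trifluoromethyl on an aromatic carbon, para to a large group. For the measured compounds named here, no pair of measured compounds shows this change directly, so its size can only be guessed from the rest of the set.

Both compounds that carry no trifluoromethyl give lower numbers than compound 2, which suggests that losing this group is more likely to lower the number than to raise it, though the halogens on compound 1 and compound 3 sit elsewhere and keep this from being a clean comparison. A modest step down is therefore expected, a 2.4-fold lower number from compound 2 to compound 4 (0.38 log units; beyond the scatter), rather than a large one. On that basis compound 4 is expected to give about 15000 nM in this assay, with a plausible range from 5000 nM to 45000 nM.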

Compound 4, half-maximal inhibitory concentration: > 100000 nM
Compound 4 was reported as a limit (the forecaster's own chance of this, stated with the estimate: 10%); at least 6.6-fold (0.82 log units) between middle value and limit.
By their numbers in this assay, from the lowest: compounds 1 and 3 (each within the scatter of the next); then compound 2. At a limit, above all of these: compound 4.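

In this assay compound 4 is reported only as a limit, > 100000 nM, and not as an exact number. Putting hydrogen in place of trifluoromethyl on this aromatic carbon, para to a large group, gives an at least 2.7-fold higher number from compound 2 to compound 4 (0.44 log units; beyond the scatter), so the group matters here even though compound 2 itself is only a weak inhibitor: without it, inhibition can no longer be given an exact number in this assay. This step is a minimum, not a measured size, and the true change could be larger, with only one compound at this limit so far: the limit of > 100000 nM in this assay, at which 1 of the 4 values shown sits.

Going by these compounds, it remains open whether trifluoromethyl itself is needed or whether other groups on the same carbon, such as a chlorine, a methyl, a nitrile or an amine, would serve as well with the rest of compound 2 unchanged. Compound 1 and compound 3 differ from compound 4 in more than one place, so they cannot show what a single halogen would do on this ring.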